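This account rests on a few compounds, and the source may have more. Where it says the series, first, only, none or still open, it means among the compounds named here.

Measured compounds:
Compound 1 `CC(C)c1ccc(-c2cc(-c3ccc4c(c3)CCCC4)nc(NCc3ccccc3)c2C#N)cc1` gives > 50000 nM in an ADME assay on RAW264.7 cells (Mus musculus) for cytotoxicity, with a stated time of 24 h (a lower number here means a stronger inhibitor, a higher number a weaker inhibitor), which is a limit of the assay and not a number.
Compound 2 `COc1ccc(-c2cc(-c3ccc4c(c3)CCCC4)nc(OCC(=O)NN)c2C#N)cc1OC` gives 3100 nM in this assay.

For the measured compounds named here, compound 2 stands as the only measured number here; the other value shown is a limit (the limit of > 50000 nM in this assay, at which 1 of the 2 values shown sits). Going by the values given here, compound 1 and compound 2 differ in two places, so no single step joins them, and their two values show only that compound 2 gives a number where compound 1 gives a limit.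

Compound 3 `CC(C)c1ccc(-c2cc(-c3ccc4c(c3)CCCC4)nc(OCC(=O)NN)c2C#N)cc1` has not yet been measured in this assay. It differs from compound 2 by 4-isopropylphenyl in place of 3,4-dimethoxyphenyl on an aromatic carbon. Compound 3 thus combines the 4-isopropylphenyl group found in compound 1, whose result in this assay is a limit, with the (aminocarbamoyl)methoxy group of compound 2. Among the compounds with values here, with no measured step joining these compounds, the expectation rests on this pairing alone: the change from compound 2 to compound 3 is expected to weaken inhibition, with a step of a 2.9-fold higher number from compound 2 to compound 3 (0.46 log units; beyond the scatter) beyond the usual scatter. Compound 3 is therefore expected to give about 9000 nM, within a range from 2500 nM to 50000 nM, and a limit rather than a number is a real possibility.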

Compound 3, half-maximal inhibitory concentration: 27700 nM
Estimate against measurement, compound 3: 3.1-fold (0.49 log units) below, and the stated range covers the measured number.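

Swapping 3,4-dimethoxyphenyl for 4-isopropylphenyl, on the aromatic carbon opposite the ring nitrogen, gives an 8.9-fold higher number from compound 2 to compound 3 (0.95 log units; beyond the scatter) in this assay, so with (aminocarbamoyl)methoxy in place, the group at this position clearly affects the read-out. Compound 1, which also carries 4-isopropylphenyl, stands at a limit of the assay and not at a number: the limit of > 50000 nM in this assay, at which 1 of the 3 values shown sits. The other change, (aminocarbamoyl)methoxy in place of benzylamino with 4-isopropylphenyl kept, gives an at least 1.8-fold lower number from compound 1 to compound 3 (0.25 log units; that floor lies within the scatter); since this floor lies within the usual scatter, the pair alone does not show that this change matters.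

From the compounds shown here alone, with only these two groups at this position, it stays open whether the step comes from losing the two methoxy groups or from gaining the isopropyl group, a question that a plain phenyl or a 4-methoxyphenyl group could help to settle. Also open, going by these compounds, are whether the same step holds when benzylamino takes the place of (aminocarbamoyl)methoxy, and how a carboxylic acid or a primary amine at the end of that chain would read in this assay.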